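From acetamido to propylcarbonyl on a shared core

A few compounds are considered here, and "the series" means these few. Any claim that something is new, unique, unknown or untested is made for them only; others in the source may bear on it.

In a functional assay on the whole organism for inhibition, with Cavia porcellus as the target (a higher number here means that more compound is needed for the effect, a lower number that less compound is needed), compound 1 (`COc1ccccc1OCC1SCCN1C(=O)CNC(C)=O`) gives 40 mg/kg, compound 2 (`COc1ccccc1OCC1SCCN1C(=O)Cn1ccnc1`) gives 50 mg/kg and compound 3 (`COc1ccccc1OCC1SCCN1C(=O)CC(C)=O`) gives 30 mg/kg. These numbers all lie within the scatter of one another, so compound 1 stands level with the other two.

Compound 4 (`CCCC(=O)CC(=O)N1CCSC1COc1ccccc1OC`) has not yet been measured. It carries propylcarbonyl in place of acetamido on a saturated chain carbon bound to a carbonyl carbon.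

Two measured changes at this same place bear on it. Putting acetyl in place of acetamido gives a 1.3-fold lower number from compound 1 to compound 3 (0.12 log units; within the scatter), and putting 1H-imidazol-1-yl there gives a 1.3-fold higher number from compound 1 to compound 2 (0.10 log units; within the scatter). Acetyl is the nearer comparison by name, yet no measurement covers propylcarbonyl itself, so the range must stay wide.

Neither step leaves the scatter, so no real shift in this assay is expected. The expected step is a 1.1-fold lower number from compound 1 to compound 4 (0.06 log units; within the scatter). Compound 4 is estimated at 35 mg/kg, with an expected range from 15 mg/kg to 80 mg/kg.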

Compound 4, dose for half-maximal effect: 42 mg/kg
The estimate for compound 4 lay 1.2-fold (0.08 log units) below the measured number; the range from low to high includes it.
By their numbers in this assay, from the lowest: compounds 3, 1, 4 and 2 (each within the scatter of the next).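

Exchanging acetamido for propylcarbonyl removes the hydrogen-bond donor of acetamido and lengthens the group, yet in this assay this gives a 1.1-fold higher number from compound 1 to compound 4 (0.02 log units; within the scatter). Putting ethyl in place of hydrogen on the acetyl group of compound 3 gives a 1.4-fold higher number from compound 3 to compound 4 (0.15 log units; within the scatter), and exchanging the 1H-imidazol-1-yl ring for the open propylcarbonyl chain gives a 1.2-fold lower number from compound 2 to compound 4 (0.08 log units; within the scatter), so neither change separates the numbers among these four compounds. No measurement is available that could explain why the numbers stay so close.

The compounds shown leave open whether an amine, a carboxylic acid or a chain longer than propylcarbonyl at this place would move the number beyond the scatter. As far as these compounds go, with every step here inside the scatter, it also remains open whether the number in this whole-organism test responds to this position at all.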